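The source may report more compounds than this note shows. Statements on the series, on what has been measured and on what is new or still open speak of the compounds shown alone.

Measured so far in a functional assay on HepG2 cells (Homo sapiens) for inhibition, read by MTT assay, with a stated time of 24 h; a higher number here means a weaker inhibitor, a lower number a stronger inhibitor:
- compound 1, `COc1ccccc1-n1cc(CN2C(=O)C[C@@H]3CC[C@@]2(C)C3(C)C)nn1`: 110 nM
- compound 2, `COc1ccc(-n2cc(CN3C(=O)C[C@@H]4CC[C@@]3(C)C4(C)C)nn2)cc1`: 100 nM
- compound 3, `CC1(C)[C@H]2CC[C@]1(C)N(Cc1cn(-c3ccccc3C#N)nn1)C(=O)C2`: 180 nM

All three share one core and differ only in the aryl group on the aromatic nitrogen. Compound 3 carries the highest of the three numbers, but the steps of a 1.6-fold higher number from compound 1 to compound 3 (0.21 log units; within the scatter) and a 1.8-fold higher number from compound 2 to compound 3 (0.26 log units; within the scatter) both sit within the scatter, as does a 1.1-fold lower number from compound 1 to compound 2 (0.04 log units; within the scatter), so the three compounds cannot be told apart on these data.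

Compound 4 `CC1(C)[C@H]2CC[C@]1(C)N(Cc1cn(-c3cccc(Br)c3)nn1)C(=O)C2` differs from compound 3 in one place: 3-bromophenyl in place of 2-cyanophenyl on an aromatic nitrogen. Going by the values given here, two measured steps bear on it. Moving the substituent around the phenyl ring, a 1.1-fold lower number from compound 1 to compound 2 (0.04 log units; within the scatter), changed nothing beyond the scatter, and exchanging one substituent for another, a 1.6-fold higher number from compound 1 to compound 3 (0.21 log units; within the scatter), did not either. Among the compounds with values here, no measured compound carries bromine, so the entering group itself is untested. On this basis the step to compound 4 is expected to be a 1.1-fold lower number from compound 3 to compound 4 (0.05 log units; within the scatter), nothing beyond the scatter. Compound 4 is therefore estimated at 160 nM, with a range of 60 nM to 450 nM.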

Compound 4, half-maximal inhibitory concentration: 20 nM
Compound 4: the middle estimate sits 8.0-fold (0.90 log units) above what was measured, outside the stated range (below it).
By their numbers in this assay, from the lowest: compound 4; then compounds 2, 1 and 3 (each within the scatter of the next).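

In this assay, the aryl group on the aromatic nitrogen proves able to move the number beyond the scatter: 3-bromophenyl gives a 9.0-fold lower number from compound 3 to compound 4 (0.95 log units; beyond the scatter) and a 5.0-fold lower number from compound 2 to compound 4 (0.70 log units; beyond the scatter) and also a 5.5-fold lower number from compound 1 to compound 4 (0.74 log units; beyond the scatter). The earlier exchanges among 2-methoxyphenyl, 4-methoxyphenyl and 2-cyanophenyl gave no such separation, so this position is not indifferent to what it carries, and compound 4 stands as the strongest inhibitor of the four. Nothing available explains why the bromine-bearing ring differs from the other three.

Compound 4 changes both the substituent and its place on the phenyl ring, and the compounds shown do not separate these two changes. They also leave open whether chlorine, a methyl group or an amine at the same place on the ring would match bromine.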